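Lengthening the thioether chain toward the assay ceiling

The source may report more compounds than this note shows. Statements on the series, on what has been measured and on what is new or still open speak of the compounds shown alone.

Compound 1 `CCCCCCCSC[C@H](NC(C)=O)C(=O)CCl` and compound 2 `CCCCCCCCCCCCCSC[C@H](NC(C)=O)C(=O)CCl` share one core and differ only in the length of the saturated chain on the sulfur. In a functional assay on MOLT-3 cells (Homo sapiens) (on this read-out lower numbers stand for stronger inhibition and higher numbers for weaker inhibition), compound 1 gives 2500 nM. In this assay compound 2 reaches only the limit > 100000 nM, so no number is known for it. The step of an at least 40-fold higher number from compound 1 to compound 2 (1.60 log units; beyond the scatter) is therefore read against (the limit of > 100000 nM in this assay, at which 1 of the 2 values shown sits), and its true size may be larger than stated. Compound 3 `CCCCCCCCCCCCCCCCSC[C@H](NC(C)=O)C(=O)CCl` carries the change (propyl in place of hydrogen on a saturated chain carbon, ten or more bonds along the chain from a sulfur), extending the same chain once more. Because the step of an at least 40-fold higher number from compound 1 to compound 2 (1.60 log units; beyond the scatter) already carried compound 2 to the limit, a further extension is expected to give no number either. The expected step that the limit leaves unreadable from compound 2 to compound 3 cannot be resolved by this assay. Compound 3 is therefore estimated at 250000 nM, within 100000 nM to 1000000 nM, and most likely reported again as a limit.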

Compound 3, half-maximal inhibitory concentration: 17300 nM
Estimate against measurement, compound 3: 14-fold (1.16 log units) above, outside the stated range (below it).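

Adding propyl at the far end of the chain gives an at least 5.7-fold lower number from compound 2 to compound 3 (0.76 log units; beyond the scatter), so in this assay inhibition does not simply fade away as the chain on the sulfur grows. Even so, the longest chain does not recover the level of the shortest one, with a 6.9-fold higher number from compound 1 to compound 3 (0.84 log units; beyond the scatter). Compound 2 gives > 100000 nM, which is a limit and not a number, so the drop on going to compound 3 is only a lower bound on its true size: the limit of > 100000 nM in this assay, at which 1 of the 3 values shown sits.

As far as these compounds go, the shape of the trend stays open, since chains of intermediate length could show whether compound 2 marks a real dip or something less regular. Equally open, from the compounds shown here alone, is how a shorter butyl chain on the sulfur, or a chain ending in a carboxylic acid, would behave.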